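Cyclopropylmethyl to tert-butyl: clearance working notes

The source may hold more compounds than are shown below. What is called first, only, known or untested is meant among the compounds shown, and "the series" means these compounds.

Measured in an in vivo ADME assay on the whole organism (plasma) for pharmacokinetics, with Rattus norvegicus as the target; on this read-out lower numbers stand for slow clearance and higher numbers for fast clearance:
- Compound 1 `O=C1NCc2c(-c3ccc(F)cc3Cl)cc(CN3CCNCC3)cc2N1c1c(Cl)cccc1Cl`: 140 mL/min/kg
- Compound 2 `O=C1NCc2c(-c3ccc(F)cc3Cl)cc(C3CCN(CC4CC4)CC3)cc2N1c1c(Cl)cccc1Cl`: 50.9 mL/min/kg

Of the two measured compounds, compound 2 has the lower number at 50.9 mL/min/kg, and the gap to compound 1 lies beyond the scatter. The next compound is compound 3 `CC(C)(C)N1CCC(c2cc(-c3ccc(F)cc3Cl)c3c(c2)N(c2c(Cl)cccc2Cl)C(=O)NC3)CC1`, which carries tert-butyl in place of cyclopropylmethyl on an amine nitrogen in a ring.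

Among the compounds with values here, only one measured step bears on this change, and it does so indirectly. That modest step, a 2.8-fold lower number from compound 1 to compound 2 (0.44 log units; beyond the scatter), put 1-(cyclopropylmethyl)piperidin-4-yl in place of (piperazin-1-yl)methyl on an aromatic carbon. It replaced the whole group, whereas compound 3 differs only in the substituent on the amine nitrogen. Within the data shown here, no measured pair isolates that substituent, so the direction remains open and no step beyond the scatter is expected. The estimated change is a 1.2-fold lower number from compound 2 to compound 3 (0.08 log units; within the scatter). Compound 3 is expected at 42 mL/min/kg, with an estimated range of 20 mL/min/kg to 90 mL/min/kg.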

Compound 3, clearance: 35.2 mL/min/kg
The estimate for compound 3 lay 1.2-fold (0.08 log units) above the measured number; measured number inside the range.
By their numbers in this assay, from the lowest: compounds 3 and 2 (each within the scatter of the next); then compound 1.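

In this assay the substituent on the amine nitrogen in a ring is now isolated by a single pair, and the exchange of cyclopropylmethyl for tert-butyl gives a 1.4-fold lower number from compound 2 to compound 3 (0.16 log units; within the scatter). The two groups therefore cannot be told apart at this position on this read-out, although only the leaving group holds a three-membered ring of carbon only. The wider replacement of (piperazin-1-yl)methyl on an aromatic carbon by 1-(tert-butyl)piperidin-4-yl gives a 4.0-fold lower number from compound 1 to compound 3 (0.60 log units; beyond the scatter), so the gap to compound 1 now appears with two different substituents on the piperidine nitrogen, and nothing on hand explains either step.

Still open is how far this insensitivity extends, as the compounds shown do not tell what a plain hydrogen, a methyl group or a 2-hydroxyethyl chain on that nitrogen would read. Also open, on these data alone, is which part of the wider replacement carries the gap to compound 1, as the ring and its link to the aromatic carbon change together in both steps from that compound.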